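Trifluoromethoxy in place of methyl on a weak compound

The compounds below may be only part of what the source reports. "The series", "measured", "known", "first", "only" and "open" are said of these compounds alone.

In a functional assay (BAEC cells, Bos taurus) for inhibition, read by cell counting, with a stated time of 3 days (a lower number here means a stronger inhibitor, a higher number a weaker inhibitor), compound 1 `COc1ccc(N(C)c2nc(C)nc3c2nc(C)n3C)cc1` gives 7400 nM as its half-maximal inhibitory concentration. Compound 2 `Cc1ccc(N(C)c2nc(C)nc3c2nc(C)n3C)cc1` gives > 100000 nM as a limit of the assay, not a number. Among the compounds with values here, the one measured step, an at least 13-fold higher number from compound 1 to compound 2 (1.13 log units; beyond the scatter) with methyl in place of methoxy on an aromatic carbon, is large and beyond the scatter. Compound 3 `Cc1nc(N(C)c2ccc(OC(F)(F)F)cc2)c2nc(C)n(C)c2n1` differs from compound 2 by trifluoromethoxy in place of methyl on an aromatic carbon in the same place on the ring. Within the data shown here, only that one measured step bears on this change, and it is read in reverse here. Trifluoromethoxy is not methoxy, so only part of an at least 13-fold higher number from compound 1 to compound 2 (1.13 log units; beyond the scatter) is expected to return, as a lower number in this assay for compound 3. An estimated at least 3.3-fold lower number from compound 2 to compound 3 (0.52 log units; beyond the scatter) is expected. The estimate for compound 3 is 30000 nM with an expected range from 7000 nM to 100000 nM in four of five measurements.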

Compound 3, half-maximal inhibitory concentration: > 100000 nM
Compound 3 was reported as a limit; the forecaster's own chance of this, stated with the estimate: 35%; middle value at least 3.3-fold (0.52 log units) away from the limit.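

In this assay, trifluoromethyl in place of methyl on the oxygen gives an at least 13-fold higher number from compound 1 to compound 3 (1.13 log units; beyond the scatter), a large step, so an oxygen on the aromatic carbon does not by itself keep a readable value. Of the three groups shown at this place, only methoxy gives a number, while trifluoromethoxy in compound 3 gives only a limit of the assay, as methyl does in compound 2. The step from compound 2 to compound 3 cannot be read because both compounds stand at the same limit: the limit of > 100000 nM in this assay, at which 2 of the 3 values shown sit.

Going by these compounds, what remains open is how far compound 2 and compound 3 lie beyond that limit. On these data alone, it is also open whether an ethoxy group or a dimethylamino group at this place would give a readable value, and how that value would stand against compound 1.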